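Ring for chain on the five-membered ring nitrogen

This account rests on a few compounds, and the source may have more. Where it says the series, first, only, none or still open, it means among the compounds named here.

Three compounds share one core and differ only at an aromatic nitrogen of the five-membered aromatic ring with 2 nitrogen. In an assay on isolated protein for inhibition of Leucine-rich repeat serine/threonine-protein kinase 2 (Homo sapiens), read by TR-FRET and LanthaScreen, with stated times of 50 min and 30 min, in the presence of a further agent that is not named here (a higher number here means a weaker inhibitor, a lower number a stronger inhibitor), compound 1 `Cc1c(Nc2nc(N)c3c(C#N)c(N4CCC[C@H]4C)n(C)c3n2)cnn1CC1(O)COC1` gives 16 nM, compound 2 `Cc1c(Nc2nc(N)c3c(C#N)c(N4CCC[C@H]4C)n(C)c3n2)cnn1C1COC1` gives 47 nM, and compound 3 `Cc1c(Nc2nc(N)c3c(C#N)c(N4CCC[C@H]4C)n(C)c3n2)cnn1CC(C)(C)O` gives 43 nM. Compound 3 thus stands second highest of the three numbers: its value and that of compound 2 lie within the scatter, as a 1.1-fold lower number from compound 2 to compound 3 (0.04 log units; within the scatter) shows, while a 2.7-fold higher number from compound 1 to compound 3 (0.43 log units; beyond the scatter) puts it beyond the scatter from compound 1.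

Compound 4 `Cc1c(Nc2nc(N)c3c(C#N)c(N4CCC[C@H]4C)n(C)c3n2)cnn1[C@@H]1CCOC1` carries oxolan-3-yl in place of 2-hydroxy-2-methylpropyl on an aromatic nitrogen. The step that bears on it most directly is a 1.1-fold lower number from compound 2 to compound 3 (0.04 log units; within the scatter), where a ring without a hydroxyl and a chain with one gave numbers within the scatter of each other. The steps of a 2.9-fold higher number from compound 1 to compound 2 (0.47 log units; beyond the scatter) and a 2.7-fold higher number from compound 1 to compound 3 (0.43 log units; beyond the scatter) were both modest. A step within the scatter, perhaps slightly upward, is therefore expected for a 1.3-fold higher number from compound 3 to compound 4 (0.11 log units; within the scatter). Compound 4 is estimated at 55 nM in this assay, with a range from 22 nM to 140 nM.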

Compound 4, half-maximal inhibitory concentration: 20 nM
Compound 4: the middle estimate sits 2.8-fold (0.44 log units) above what was measured; the measured number lies below the stated range.
By their numbers in this assay, from the lowest: compounds 1 and 4 (each within the scatter of the next); then compounds 3 and 2 (each within the scatter of the next).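

In this assay the open chain and the ring at this aromatic nitrogen are not interchangeable, even with the same count of heavy atoms: oxolan-3-yl replacing 2-hydroxy-2-methylpropyl gives a step beyond the scatter (a 2.2-fold lower number from compound 3 to compound 4 (0.33 log units; beyond the scatter)). Ring identity also counts, as the step from oxetan-3-yl to oxolan-3-yl shows (a 2.4-fold lower number from compound 2 to compound 4 (0.37 log units; beyond the scatter)), so the earlier match between oxetan-3-yl and the chain does not extend to every ring. A hydrogen-bond donor in this group is not required for a number in the range of compound 1, since oxolan-3-yl has none and remains within the scatter of (3-hydroxyoxetan-3-yl)methyl (a 1.3-fold higher number from compound 1 to compound 4 (0.10 log units; within the scatter)).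

No measurement shown explains any of these steps.
Going by these compounds, the opposite configuration at the oxolan-3-yl stereocentre remains open, as do a tetrahydropyran-4-yl ring and an aminoethyl chain on this nitrogen.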